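The source may report more compounds than this note shows. Statements on the series, on what has been measured and on what is new or still open speak of the compounds shown alone.

Measured in a functional assay on MGC-803 cells (Homo sapiens) for inhibition, read by MTT assay, with a stated time of 72 h; on this read-out lower numbers stand for stronger inhibition and higher numbers for weaker inhibition:
Compound 1 `O=C(CSc1nc(Nc2ccccc2)c2ccccc2n1)Nc1ccc(C(F)(F)F)cc1` gives 8670 nM.
Compound 2 `CCc1ccc(NC(=O)CSc2nc(Nc3ccccc3)c3ccccc3n2)cc1` gives > 50000 nM, which is a limit of the assay.
Compound 3 `C=CC(=O)Nc1cccc(NC(=O)CSc2nc(Nc3ccc(C(F)(F)F)cc3)c3ccccc3n2)c1` gives 12100 nM.

Compound 1 and compound 3 differ in more than one place; the difference between the two cores is not broken down here. On the core of compound 1, the change ethyl in place of trifluoromethyl on an aromatic carbon gives an at least 5.7-fold higher number from compound 1 to compound 2 (0.76 log units; beyond the scatter), with compound 2 sitting at the limit of > 50000 nM in this assay, at which 1 of the 3 values shown sits. Compound 4 `C=CC(=O)Nc1cccc(NC(=O)CSc2nc(Nc3ccc(CC)cc3)c3ccccc3n2)c1` carries the same change on the core of compound 3, namely (ethyl in place of trifluoromethyl on an aromatic carbon), at the same place as in the first pair. Resting on an at least 5.7-fold higher number from compound 1 to compound 2 (0.76 log units; beyond the scatter), compound 4 is expected to give 60000 nM in this assay, with a fair chance that only a limit is reported. The expected step is a 5.0-fold higher number from compound 3 to compound 4 (0.70 log units; beyond the scatter). The expected range for compound 4 runs from 20000 nM to 200000 nM.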

Compound 4, half-maximal inhibitory concentration: 8010 nM
Compound 4: middle estimate off by 7.5-fold (0.87 log units), on the high side; measured number outside the range, below it.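

On the core of compound 3, ethyl in place of trifluoromethyl gives a 1.5-fold lower number from compound 3 to compound 4 (0.18 log units; within the scatter) in this assay, so the result on the core of compound 1 does not carry over to this core: the same change on two cores in this assay, an at least 5.7-fold higher number (0.76 log units; beyond the scatter) from compound 1 to compound 2 and a 1.5-fold lower number (0.18 log units; within the scatter) from compound 3 to compound 4, at least 8.7-fold (0.94 log units) apart, beyond the scatter of two such steps. Compound 2 gives > 50000 nM, which is a limit of the assay, so the step on the core of compound 1 has no exact size. These two pairs show that the outcome of this change differs between the two cores, but not which difference between the cores accounts for it.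

As far as these compounds go, it remains open how the two cores respond to other groups at this place, such as a carboxylic acid, an amine or a longer alkyl chain. A further pair on each core would show whether the difference holds beyond ethyl and trifluoromethyl.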